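The source may report more compounds than this note shows. Statements on the series, on what has been measured and on what is new or still open speak of the compounds shown alone.

Series notes. Compound 1 `Oc1cccc(/C=C/c2ccccc2O)c1` gives 18 ug/mL in an ADME assay on HEK293 cells (Homo sapiens) for inhibition, read by MTT assay, with a stated time of 2 days; on this read-out lower numbers stand for stronger inhibition and higher numbers for weaker inhibition. Compound 2 `Nc1cccc(/C=C/c2ccccc2O)c1` gives 96 ug/mL in this assay. The change from compound 1 to compound 2 is amino in place of hydroxy on an aromatic carbon and the measured step is a 5.3-fold higher number from compound 1 to compound 2 (0.73 log units; beyond the scatter).

Compound 3 `COc1cccc(/C=C/c2cccc(O)c2)c1` gives 19 ug/mL in this assay. Its number and that of compound 1 lie within the scatter of each other, while compound 2 stands clearly apart from both. The difference between the core of compound 1 and the core of compound 3 is not broken down here.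

Compound 4 `COc1cccc(/C=C/c2cccc(N)c2)c1` has not yet been measured in this assay. It arises from compound 3 by amino in place of hydroxy on an aromatic carbon. This is the same kind of change as that made from compound 1 to compound 2, not the same change: in compound 3 the place is meta to a large group, whereas in compound 1 it is meta to a group of 9 heavy atoms. It is the only other occurrence of the change among the compounds shown.

Within the data shown here, a step of similar size is expected, a 4.5-fold higher number from compound 3 to compound 4 (0.65 log units; beyond the scatter), because the single measured instance gave a 5.3-fold higher number from compound 1 to compound 2 (0.73 log units; beyond the scatter). Compound 4 is therefore estimated at 85 ug/mL, with a range from 35 ug/mL to 200 ug/mL. The expectation rests on one precedent only, and the range is set wide to allow for that.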

Compound 4, half-maximal inhibitory concentration: 16 ug/mL
For compound 4 the middle estimate is 5.3-fold (0.73 log units) above the measured one, outside the stated range (below it).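

In this assay the step for amino in place of hydroxy on an aromatic carbon, made on the core of compound 3, is a 1.2-fold lower number from compound 3 to compound 4 (0.07 log units; within the scatter) and leaves the two compounds indistinguishable on this read-out. The size of the step seen on the core of compound 1 therefore did not carry over to the core of compound 3, so a step measured on one core in this series cannot be treated as a fixed increment for the same change on another. This shows only that the size of the step differs between these two cores, not which feature of the cores goes with the difference, and two occurrences give no rule for any further core: the same change on two cores in this assay, a 5.3-fold higher number (0.73 log units; beyond the scatter) from compound 1 to compound 2 and a 1.2-fold lower number (0.07 log units; within the scatter) from compound 3 to compound 4, 6.3-fold (0.80 log units) apart, beyond the scatter of two such steps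

The compounds shown leave open which of the two steps is the more usual one for this change, a question that only further matched pairs on other cores could settle. Also open, going by these compounds, is how other groups on the same aromatic carbon, such as a dimethylamino group or a carboxylic acid, would read in this assay on either core.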